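The compounds below may be only part of what the source reports. "The series", "measured", "known", "first", "only" and "open" are said of these compounds alone.

In a functional assay on CNE-2 cells (Homo sapiens) for antiproliferative activity, read by sulforhodamine B assay, with a stated time of 48 h (on this read-out lower numbers stand for stronger inhibition and higher numbers for weaker inhibition), compound 1 `COc1ccc(/C=C/C(=O)c2ccccc2-c2ccc(OC)c(OC)c2)cc1OC` gives 2500 nM, compound 2 `COc1ccc(/C=C/C(=O)c2ccccc2-c2ccc(F)cc2)cc1OC` gives 81 nM and compound 3 `COc1ccc(/C=C/C(=O)c2ccccc2-c2ccc(F)cc2)cc1B(O)O` gives 21 nM, which places compound 2 second highest of the three. Compound 4 `COc1ccc(/C=C/C(=O)c2ccccc2-c2cccc(F)c2)cc1OC` is unmeasured. Its change from compound 2 is 3-fluorophenyl in place of 4-fluorophenyl, ortho to a large group: 3-fluorophenyl in place of 4-fluorophenyl on an aromatic carbon. Within the data shown here, the nearest precedent replaces the same substituent, with a large step: a 31-fold lower number from compound 1 to compound 2 (1.49 log units; beyond the scatter). The other step, a 3.9-fold lower number from compound 2 to compound 3 (0.59 log units; beyond the scatter), is modest and lies at a different place. Neither moves a fluorine, so a modest rise in this assay is expected, well short of the large step. The expected change is a 2.0-fold higher number from compound 2 to compound 4 (0.30 log units; within the scatter). Compound 4 is estimated at 160 nM, with an expected range of 50 nM to 500 nM.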

Compound 4, half-maximal inhibitory concentration: 650 nM
The estimate for compound 4 lay 4.1-fold (0.61 log units) below the measured number; the measured number lies above the stated range.
By their numbers in this assay, from the lowest: compound 3; then compound 2; then compound 4; then compound 1.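

Among the fluorophenyl groups, where the fluorine sits matters: with the same atoms joined differently, 3-fluorophenyl in place of 4-fluorophenyl gives an 8.0-fold higher number from compound 2 to compound 4 (0.90 log units; beyond the scatter). The gain over 3,4-dimethoxyphenyl therefore does not follow from having a fluorophenyl group alone, although 3-fluorophenyl still retains an advantage, with a 3.8-fold lower number from compound 1 to compound 4 (0.59 log units; beyond the scatter). No measurement available here explains the difference between the two fluorophenyl groups. Open, from the compounds shown here alone, is whether 4-chlorophenyl or 4-aminophenyl would match 4-fluorophenyl at this place. Also open, going by these compounds, is whether the boronic acid of compound 3 would give a similar gain alongside 3-fluorophenyl.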